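Trifluoromethoxy in Place of Methyl on Compound 3

A few compounds are considered here, and "the series" means these few. Any claim that something is new, unique, unknown or untested is made for them only; others in the source may bear on it.

Compound 1 `Cc1ccc(-c2ncccn2)c(C(=O)N2CC3(CC3)C[C@H]2CNc2cc(C(F)(F)F)ccn2)n1` in a functional assay on HEK293 cells for antagonist activity at Orexin receptor type 2 (Homo sapiens), read by FLIPR and calcium flux (a higher number here means a more potent compound, by a factor of ten per unit of this negative logarithm, a lower number a less potent compound), gives 8.1.
Compound 2 `Cc1cnn(-c2ccc(C)nc2C(=O)N2CC3(CC3)C[C@H]2CNc2ccc(C(F)(F)F)cn2)c1` gives 8.3.
Compound 3 `Cc1ccc(-c2ncccn2)c(C(=O)N2CC3(CC3)C[C@H]2CNc2ccc(C(F)(F)F)cn2)n1` gives 7.5.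

Compound 3 stands lowest of the three numbers. The step of a number 0.60 log units lower from compound 1 to compound 3 (beyond the scatter) and the step of a number 0.80 log units lower from compound 2 to compound 3 (beyond the scatter) both end at it. Compound 4 `O=C(c1nc(OC(F)(F)F)ccc1-c1ncccn1)N1CC2(CC2)C[C@H]1CNc1ccc(C(F)(F)F)cn1` differs from compound 3 by trifluoromethoxy in place of methyl on an aromatic carbon. Going by the values given here, neither measured step touches this position; one changes the aryl group on the amine nitrogen, the other the group on an aromatic carbon elsewhere, so no measured step bears directly on the change. Without such a comparison, compound 4 is expected to stay near compound 3, with a step of no change at the digits printed from compound 3 to compound 4 (within the scatter) not beyond the scatter. The estimate for compound 4 in this assay is 7.5, within 6.9 to 8.1.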

Compound 4, negative logarithm of the antagonist equilibrium constant: 6.9
Estimate against measurement, compound 4: 0.60 log units above; the measured number falls inside the stated range.
By their numbers in this assay, from the lowest: compound 4; then compound 3; then compounds 1 and 2 (each within the scatter of the next).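

At this position, next to the ring nitrogen, the group is not a neutral choice: in this assay trifluoromethoxy in place of methyl gives a number 0.60 log units lower from compound 3 to compound 4 (beyond the scatter), a step beyond the scatter. The earlier steps shown here changed other places and said nothing about this one. Nothing at hand accounts for the drop. As far as these compounds go, whether a methoxy group, a chlorine atom or an amine here would keep the number of compound 3 stays open. So does whether the same change would cost as much alongside the 4-methyl-1H-pyrazol-1-yl group of compound 2.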